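The source may report more compounds than this note shows. Statements on the series, on what has been measured and on what is new or still open speak of the compounds shown alone.

Measured compounds:
Compound 1 `C#CCN(c1nc(-c2cccc(Br)c2)no1)C1CCCCC1`: 31.8 ug/mL
Compound 2 `CC(=O)OC[C@H]1O[C@H](OC[C@H](Cn2cc(COc3ccc(-c4noc(C)n4)cc3)nn2)OC(C)=O)C=C[C@@H]1OC(C)=O`: 112 ug/mL

In an ADME assay on RAW264.7 cells (Mus musculus) for cytotoxicity, read by MTT assay, with a stated time of 48 h (on this read-out lower numbers stand for higher toxicity in this test and higher numbers for lower toxicity in this test), compound 1 stands at the lowest of the two numbers, with 31.8 ug/mL. Compound 2 gives 112 ug/mL, a higher number that lies beyond the scatter, so compound 2 is the less toxic of the two.

Compound 3 `C#CCN(c1nc(-c2ccc(Br)cc2)no1)C1CCCCC1` differs from compound 1 in one place: 4-bromophenyl in place of 3-bromophenyl on an aromatic carbon. Going by the values given here, no measured step of this kind is available among the compounds, so the expected change in this assay is small, within the scatter and without a clear direction. Compound 3 is therefore expected to give about 35 ug/mL, in a range from 15 ug/mL to 80 ug/mL, an estimated step of a 1.1-fold higher number from compound 1 to compound 3 (0.04 log units; within the scatter).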

Compound 3, half-maximal cytotoxic concentration: 15.7 ug/mL
The estimate for compound 3 lay 2.2-fold (0.35 log units) above the measured number; measured number inside the range.
By their numbers in this assay, from the lowest: compound 3; then compound 1; then compound 2.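

Exchanging 3-bromophenyl for 4-bromophenyl on the shared core, with the same atoms joined differently, gives a 2.0-fold lower number from compound 1 to compound 3 (0.31 log units; beyond the scatter) in this assay. Going by these compounds alone, this modest step shows that the read-out at this position responds to how the bromine-bearing ring is joined, not only to which atoms are present, which the earlier compounds could not show. No measurement given here explains this step. From the compounds shown here alone, what remains open is whether a plain phenyl or a chlorophenyl at the same position would give a similar number, and whether the step depends on bromine at all.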